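The source may report more compounds than this note shows. Statements on the series, on what has been measured and on what is new or still open speak of the compounds shown alone.

Series notes. Compound 1 `COc1ccc(-c2cc(-c3ccc(OC)cc3)on2)cc1` gives in a functional assay on HeLa cells (Homo sapiens) for antiproliferative activity, read by cell counting, with a stated time of 5 days (a lower number here means a stronger inhibitor, a higher number a weaker inhibitor), only a limit, > 100000 nM. Compound 2 `COc1ccc(-c2noc(-c3ccc(OC)cc3)c2C)cc1` likewise gives only a limit in this assay, > 100000 nM. The step that the two limits leave unreadable from compound 1 to compound 2 is unreadable because both values are the limit of > 100000 nM in this assay, at which 2 of the 3 values shown sit. For the measured compounds named here, compound 3 `Oc1ccc(-c2cc(-c3ccc(O)cc3)on2)cc1` stands as the only number in the set, giving 6000 nM in this assay. Compound 4 `CCc1c(-c2ccc(O)cc2)noc1-c1ccc(O)cc1` differs from compound 3 by ethyl in place of hydrogen on an aromatic carbon. Going by the values given here, the only measured step that bears on a substituent on an aromatic carbon of the five-membered ring, a step that the two limits leave unreadable from compound 1 to compound 2, carries no readable size, so no step beyond the scatter is assumed. The expected step is no change at the digits printed from compound 3 to compound 4 (within the scatter), nothing beyond the scatter. Compound 4 is estimated at 6000 nM, with a range from 2000 nM to 20000 nM.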

Compound 4, half-maximal inhibitory concentration: 16000 nM
Compound 4: the middle estimate sits 2.7-fold (0.43 log units) below what was measured; the range from low to high includes it.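

For the compounds shown here, with the two 4-hydroxyphenyl groups in place, a substituent on this aromatic carbon of the five-membered ring has a readable effect for the first time: ethyl in place of hydrogen gives a 2.7-fold higher number from compound 3 to compound 4 (0.43 log units; beyond the scatter). Compound 4 still returns a number, so this change weakens the inhibitor without taking its value out to a limit, whereas the step from compound 1 to compound 2 cannot be read. Nothing measured here gives a cause for the step.

Going by these compounds, how a longer chain such as propyl, or an amine, on this carbon would compare with ethyl remains open. So does the size of the step for methyl when both 4-hydroxyphenyl groups are present.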